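The source may report more compounds than this note shows. Statements on the series, on what has been measured and on what is new or still open speak of the compounds shown alone.

Measured so far in an assay on CHO cells for antagonist activity at transient receptor potential cation channel subfamily V member 1 (Homo sapiens), read by FLIPR; on this read-out lower numbers stand for stronger inhibition and higher numbers for weaker inhibition:
compound 1 `CC1CCN(c2cc(C(F)(F)F)ccc2CNC(=O)C(C)c2ccc(NS(C)(=O)=O)c(F)c2)CC1` gives 0.9 nM
compound 2 `CC(C(=O)NCc1ccc(C(F)(F)F)cc1N1CCC(C)(C)CC1)c1ccc(NS(C)(=O)=O)c(F)c1` gives 1.3 nM
compound 3 `CCCCCCSc1cc(C(F)(F)F)ccc1CNC(=O)C(C)c1ccc(NS(C)(=O)=O)c(F)c1` gives 1.8 nM

Compound 2 sits in the middle of the three numbers, flanked by compound 1 and compound 3: a 1.4-fold higher number from compound 1 to compound 2 (0.16 log units; within the scatter) and a 1.4-fold higher number from compound 2 to compound 3 (0.14 log units; within the scatter). Neither step is beyond the scatter, so this assay does not separate the three.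

Compound 4 `CC(C(=O)NCc1ccc(C(F)(F)F)cc1SCc1ccco1)c1ccc(NS(C)(=O)=O)c(F)c1` is the next candidate. Its change from compound 2: ((furan-2-yl)methyl)sulfanyl in place of 4,4-dimethylpiperidin-1-yl on an aromatic carbon. The step that bears most directly on it is the replacement of the same 4,4-dimethylpiperidin-1-yl group by hexylsulfanyl, a 1.4-fold higher number from compound 2 to compound 3 (0.14 log units; within the scatter); the parallel replacement of 4-methylpiperidin-1-yl in compound 1, a 2.0-fold higher number from compound 1 to compound 3 (0.30 log units; within the scatter), likewise stays within the scatter. Both show that exchanging the saturated ring for a sulfanyl-linked substituent at this carbon moves the number little. Going by the values given here, no measured compound carries ((furan-2-yl)methyl)sulfanyl, so the step is expected to resemble those two: a slightly higher number, not beyond the scatter, a 1.5-fold higher number from compound 2 to compound 4 (0.19 log units; within the scatter). Compound 4 is therefore estimated at 2 nM, with a range of 0.7 nM to 6 nM.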

Compound 4, inhibition constant: 3.2 nM
Compound 4: the middle estimate sits 1.6-fold (0.20 log units) below what was measured; the measured number falls inside the stated range.
By their numbers in this assay, from the lowest: compounds 1, 2, 3 and 4 (each within the scatter of the next, the first and the last beyond it).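

In this assay the exchange of a saturated ring for a sulfanyl-linked group at this aromatic carbon now moves the number beyond the scatter, by a modest amount, with ((furan-2-yl)methyl)sulfanyl replacing either 4,4-dimethylpiperidin-1-yl (a 2.5-fold higher number from compound 2 to compound 4 (0.39 log units; beyond the scatter)) or 4-methylpiperidin-1-yl (a 3.6-fold higher number from compound 1 to compound 4 (0.55 log units; beyond the scatter)). Between the two sulfanyl-linked groups, furan-2-yl in place of pentyl stays inside the scatter (a 1.8-fold higher number from compound 3 to compound 4 (0.25 log units; within the scatter)), so this read-out does not separate hexylsulfanyl from ((furan-2-yl)methyl)sulfanyl. Nothing on hand accounts for the shift away from the piperidines.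

As far as these compounds go, whether the higher number follows the furan ring or the sulfur link stays open, and a benzylsulfanyl or a ((furan-2-yl)methyl)amino group at this carbon would bear on that. Also open, from the compounds shown here alone, is how a morpholin-4-yl group would stand against the piperidines of compound 1 and compound 2.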